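Lengthening the chain on compound 3 by an octyl group

The source may report more compounds than this note shows. Statements on the series, on what has been measured and on what is new or still open speak of the compounds shown alone.

Measured in a functional assay on MGC-803 cells (Homo sapiens) for antiproliferative activity, read by MTT assay, with a stated time of 48 h; on this read-out higher numbers stand for weaker inhibition and lower numbers for stronger inhibition:
Compound 1 `CCCCCCCn1cc(COC[C@@H]2OC[C@H](N)[C@@H]2O)nn1`: > 128000 nM (a limit)
Compound 2 `CCCCCCCCn1cc(COC[C@@H]2OC[C@H](N)[C@@H]2O)nn1`: 70400 nM
Compound 3 `CCCCCCCCn1cc(COC[C@@H]2OC[C@H](N)[C@H]2O)nn1`: > 128000 nM (a limit)

Compound 3 gives only a limit and no number. That position is the limit of > 128000 nM in this assay, at which 2 of the 3 values shown sit. Compound 4 `CCCCCCCCCCCCCCCCn1cc(COC[C@@H]2OC[C@H](N)[C@H]2O)nn1` keeps the configuration of compound 3 and differs from it in the chain. The change is octyl in place of hydrogen on a saturated chain carbon, eight bonds along the chain from an aromatic nitrogen.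

Among the compounds with values here, two measured steps bear on this. Within the data shown here, the only chain step is an at least 1.8-fold lower number from compound 1 to compound 2 (0.25 log units; that floor lies within the scatter), for a single methyl in place of hydrogen. It is a floor, not a measured size, and it points toward stronger inhibition. The second step is an at least 1.8-fold higher number from compound 2 to compound 3 (0.25 log units; that floor lies within the scatter), which goes with the fact that compounds 2 and 3 differ only in the configuration as drawn. It is also a floor and points the other way, so the configuration of compound 3 gives no support for a gain by itself. Neither step shows a size beyond the scatter, so the direction of the chain step is only a hint. An octyl group adds far more chain than a methyl, so a clearly larger move toward stronger inhibition is expected, though this assay may still return only a limit. The expected step is an at least 5.1-fold lower number from compound 3 to compound 4 (0.70 log units; beyond the scatter). Compound 4 is estimated at 25000 nM, with an expected range from 6000 nM to 100000 nM.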

Compound 4, half-maximal inhibitory concentration: 5340 nM
The estimate for compound 4 lay 4.7-fold (0.67 log units) above the measured number; the measured number lies below the stated range.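

In this assay, octyl in place of hydrogen on a saturated chain carbon, eight bonds along the chain from an aromatic nitrogen, gives an at least 23-fold lower number from compound 3 to compound 4 (1.37 log units; beyond the scatter), the first chain step shown that lies beyond the scatter. This size is only a floor and the full step cannot be read, since the starting point is a limit and not a number: the limit of > 128000 nM in this assay, at which 2 of the 4 values shown sit. Compound 4 keeps the drawn configuration of compound 3 and still gives a measured number, so this configuration does not by itself hold a compound at the limit, which is a point the earlier compounds could not settle, as their only comparison of configuration was this one: the fact that compounds 2 and 3 differ only in the configuration as drawn

The compounds shown leave open whether the configuration of compound 2 would give a lower or a higher number when carried on the chain of compound 4, so the effect of configuration on this longer chain remains unknown. They also leave open whether the gain continues with a still longer chain, and whether it survives an amine or a carboxylic acid placed on the chain.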